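This account rests on a few compounds, and the source may have more. Where it says the series, first, only, none or still open, it means among the compounds named here.

Compound 3 `O=C(O)CSc1nc(SCc2ccccc2)nc(=O)[nH]1` carries a (carboxymethyl)sulfanyl group on the shared core. Among the compounds with values here, in an assay for inhibition of Pro-cathepsin H (Homo sapiens), read by fluorescence, tested at 50 uM (on this read-out higher numbers stand for more inhibition at the one concentration tested (going by the name of the read-out) and lower numbers for less inhibition), compound 3 gives 6.89%, the highest of the three numbers measured so far. Compound 1 `N#Cc1ccc(CSc2nc(SCc3ccccc3)nc(=O)[nH]2)cc1` gives 1.55% in this assay, and compound 2 `CCSc1nc(SCc2ccccc2)nc(=O)[nH]1` gives -4.06%. The step of a number 5.3 percentage points higher from compound 1 to compound 3 (within the scatter) lies within the scatter, whereas a number 11 percentage points higher from compound 2 to compound 3 (beyond the scatter) lies beyond it, so only the exchange of methyl for carboxy has produced a visible difference.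

Compound 4 `O=c1nc(SCc2ccccc2)nc(SCC2CCC2)[nH]1` has not yet been measured. It differs from compound 3 in one place: cyclobutyl in place of carboxy on a saturated chain carbon bound to a sulfur. The step that bears most directly on this change is a number 11 percentage points higher from compound 2 to compound 3 (beyond the scatter); in that step carboxy replaced a group made of carbon only. The step of a number 5.3 percentage points higher from compound 1 to compound 3 (within the scatter) points the same way but stays within the scatter. Removing carboxy again is therefore expected to undo that modest gain in this assay. Compound 4 is expected to show a number 8.9 percentage points lower from compound 3 to compound 4 (within the scatter). For compound 4 the estimate is -2%, with a range from -12% to 8%.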

Compound 4, a percentage reported as inhibition, at one concentration (the size of the read-out at that concentration, not a potency): 1.57%
Compound 4: middle estimate off by 3.6 percentage points, on the low side; the range from low to high includes it.
By their numbers in this assay, from the lowest: compounds 2, 1, 4 and 3 (each within the scatter of the next, the first and the last beyond it).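

Cyclobutyl on a saturated chain carbon bound to a sulfur leaves compound 4 inseparable from the other three compounds in this assay: the steps read a number 5.3 percentage points lower from compound 3 to compound 4 (within the scatter), a number 5.6 percentage points higher from compound 2 to compound 4 (within the scatter) and a number 0 percentage points higher from compound 1 to compound 4 (within the scatter). Within the data shown here, a group of carbon only, with no hydrogen-bond donor or acceptor, therefore cannot be told apart from carboxy here, so the one visible difference at this position remains the single exchange of methyl for carboxy, not a general gap between carboxy and carbon-only groups. No measurement shown accounts for these numbers.

An amine or a longer carbon chain at this place could show whether any group moves the number clear of the scatter. A second acid, such as a longer chain ending in a carboxylic acid, could test whether the gain over methyl recurs.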